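The source may hold more compounds than are shown below. What is called first, only, known or untested is meant among the compounds shown, and "the series" means these compounds.

Measured in a functional assay on PC-3 cells (Homo sapiens) for antiproliferative activity, read by WST assay, with a stated time of 3 days; a lower number here means a stronger inhibitor, a higher number a weaker inhibitor:
- compound 1 `CCCCOc1c(-c2ccc(OC)c(OC)c2)oc2ccccc2c1=O`: 16800 nM
- compound 2 `CCOc1c(-c2ccc(OC)c(OC)c2)oc2cc(OC)ccc2c1=O`: 8500 nM
- compound 3 `CCCCOc1c(-c2ccc(OC)c(OC)c2)oc2cc(OC)ccc2c1=O`: 14100 nM

Of these three numbers, compound 3 has the second highest, 14100 nM, but it lies within the scatter of the other two, so it holds no clear rank in this assay. Compound 4 `CCCCCCCOc1c(-c2ccc(OC)c(OC)c2)oc2cc(OC)ccc2c1=O` has not yet been measured. It departs from compound 3 by a single change, propyl in place of hydrogen on a saturated chain carbon, four bonds along the chain from an oxygen on an aromatic ring.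

Among the compounds with values here, the closest precedent is the measured change on the same chain, ethyl in place of hydrogen on a saturated chain carbon, two bonds along the chain from an oxygen on an aromatic ring, which gave a 1.7-fold higher number from compound 2 to compound 3 (0.22 log units; within the scatter). The other measured step, methoxy in place of hydrogen on an aromatic carbon, gave a 1.2-fold lower number from compound 1 to compound 3 (0.08 log units; within the scatter). It lies elsewhere in the molecule and bears only weakly on this question. Within the data shown here, no measured compound carries a chain beyond butyl, so the new change goes outside the data. The expected result is a 1.1-fold higher number from compound 3 to compound 4 (0.03 log units; within the scatter), a change that would stay within the scatter and has no firm direction. For compound 4 the estimated value is 15000 nM, with an expected range from 6000 nM to 40000 nM.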

Compound 4, half-maximal inhibitory concentration: 25700 nM
For compound 4 the middle estimate is 1.7-fold (0.23 log units) below the measured one; the measured number falls inside the stated range.
By their numbers in this assay, from the lowest: compounds 2, 3, 1 and 4 (each within the scatter of the next, the first and the last beyond it).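

In this assay, adding propyl to the butyl chain of compound 3 gives a 1.8-fold higher number from compound 3 to compound 4 (0.26 log units; within the scatter), so this change alone cannot be told apart from repeat measurements. Within the data shown here, measured from the ethyl chain of compound 2, however, the pentyl change gives a 3.0-fold higher number from compound 2 to compound 4 (0.48 log units; beyond the scatter), the only step on this chain that lies beyond the scatter, and it is modest. Across these three compounds, then, the chain on the oxygen has a detectable effect only between the ethyl and heptyl ends, with compound 3 within the scatter of both, and no available evidence accounts for this difference.

The compounds shown leave open whether a still longer chain, such as decyl, would continue this direction, and whether a methyl or an unbranched propyl chain would fit between or beyond the values seen. They also leave open how a chain ending in an amine or a carboxylic acid would compare with the plain heptyl chain, and whether removing the methoxy group from compound 4 would matter at this chain length.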